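This account rests on a few compounds, and the source may have more. Where it says the series, first, only, none or still open, it means among the compounds named here.

Measured so far in an ADME assay on MT4 cells (Homo sapiens) for cytotoxicity, read by MTT assay; a lower number here means that less compound is tolerated, a higher number that more compound is tolerated:
- Compound 1 `O=C1c2ccccc2C(=O)N1CCOC(=S)N(C(=O)c1ccccc1[N+](=O)[O-])c1ccc(Cl)cc1` at 21000 nM
- Compound 2 `O=C1c2ccccc2C(=O)N1CCOC(=S)N(C(=O)c1ccc(Br)cc1)c1ccc(Br)cc1` at 73000 nM
- Compound 3 `Cc1ccc(N(C(=O)c2ccccc2[N+](=O)[O-])C(=S)OCCN2C(=O)c3ccccc3C2=O)cc1` at 100000 nM

Compound 3 at 100000 nM cannot be told apart from compound 2 at 73000 nM on these numbers, and both numbers sit above that of compound 1. Among the compounds with values here, compound 4 `Cc1ccc(N(C(=O)c2c(F)cccc2F)C(=S)OCCN2C(=O)c3ccccc3C2=O)cc1` keeps the rest of compound 3 but carries 2,6-difluorophenyl in place of 2-nitrophenyl on a carbonyl carbon as its one change.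

Within the data shown here, the only measured single step is a 4.8-fold higher number from compound 1 to compound 3 (0.68 log units; beyond the scatter) and it concerns methyl in place of chloro on an aromatic carbon, which is a different place in the molecule. Compound 2 has another group on that carbonyl carbon and still gives 73000 nM but it also differs from compound 3 in a second place. No measurement isolates this swap, so no step beyond the scatter is expected in this assay here. The expected step is a 1.4-fold lower number from compound 3 to compound 4 (0.15 log units; within the scatter) and it remains a rough expectation.

For compound 4 the estimated value is 70000 nM with an expected range from 25000 nM to 130000 nM for a measurement.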

Compound 4, half-maximal cytotoxic concentration: 65000 nM
The estimate for compound 4 lay 1.1-fold (0.03 log units) above the measured number, and the stated range covers the measured number.
By their numbers in this assay, from the lowest: compound 1; then compounds 4, 2 and 3 (each within the scatter of the next).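

In this assay, within the data shown here, the change from 2-nitrophenyl to 2,6-difluorophenyl on a carbonyl carbon gives a 1.5-fold lower number from compound 3 to compound 4 (0.19 log units; within the scatter) and this is the first reading that isolates this position. The two compounds differ only in this group, and the assay cannot separate them, even though the entering group has no hydrogen-bond acceptors and the leaving group has 2. Nothing measured here bears on the reason for this result.

Going by these compounds, it remains open whether an amine, a carboxylic acid or a longer chain in place of these aromatic groups on the carbonyl carbon would also leave the number within the scatter. On these data alone, it is also open whether this same swap would read alike on the core of compound 1, which carries chloro where compound 3 carries methyl.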